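The source may hold more compounds than are shown below. What is called first, only, known or untested is meant among the compounds shown, and "the series" means these compounds.

Working notes on the series. Among the compounds with values here, in a functional assay on cells for agonist activity at Free fatty acid receptor 1 (Homo sapiens), read by calcium flux (on this read-out higher numbers stand for an effect only at larger amounts of compound and lower numbers for an effect already at smaller amounts), compound 2 `CC#CC(CC(=O)O)c1ccc(OCc2cccc(-c3c(C)cc(OCCCS(C)(=O)=O)cc3C)c2)s1` gives 240 nM; its only neighbour among the measured compounds, compound 1 `CC#CC(CC(=O)O)c1ccc(OCc2cccc(-c3c(C)cccc3C)c2)s1`, gives 210 nM in this assay, and the two numbers sit within the scatter of each other. Within the data shown here, the single measured step, a 1.1-fold higher number from compound 1 to compound 2 (0.06 log units; within the scatter), consists of 3-(methylsulfonyl)propoxy in place of hydrogen on an aromatic carbon and left the read-out unchanged within the scatter.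

Compound 3 `CC#CC(CC(=O)O)c1ccc(OCc2cccc(-c3c(C)cc(OCC4(C)COC4)cc3C)c2)s1` has not yet been measured. It differs from compound 2 by 3-methyloxetan-3-yl in place of 2-(methylsulfonyl)ethyl on a saturated chain carbon bound to an oxygen on an aromatic ring. The measured step bears on this directly, since the entire tail on that aromatic oxygen was introduced there: because a 1.1-fold higher number from compound 1 to compound 2 (0.06 log units; within the scatter) showed no shift beyond the scatter for the whole tail, reworking only its outer part is expected to give no step beyond the scatter either, a 1.0-fold lower number from compound 2 to compound 3 (0.02 log units; within the scatter). Compound 3 is therefore estimated at 230 nM in this assay, with an expected range from 100 nM to 550 nM.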

Compound 3, half-maximal effective concentration: 450 nM
Compound 3: the middle estimate sits 2.0-fold (0.29 log units) below what was measured; the measured number falls inside the stated range.
By their numbers in this assay, from the lowest: compounds 1, 2 and 3 (each within the scatter of the next, the first and the last beyond it).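

In this assay, 3-methyloxetan-3-yl in place of 2-(methylsulfonyl)ethyl on a saturated chain carbon bound to an oxygen on an aromatic ring gives a 1.9-fold higher number from compound 2 to compound 3 (0.27 log units; within the scatter), so the two tails cannot be told apart on this read-out. Within the data shown here, measured against hydrogen on the aromatic carbon, however, (3-methyloxetan-3-yl)methoxy gives a 2.1-fold higher number from compound 1 to compound 3 (0.33 log units; beyond the scatter), the first step at this position to pass the scatter, and only modestly. No evidence on any property of these compounds is available to account for this.

A terminal amine, a carboxylic acid or a longer chain on that aromatic oxygen lies outside the compounds shown. As far as these compounds go, it stays open whether any tail here can give a lower number than compound 1 beyond the scatter.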